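From 4-chlorophenyl to phenyl at the assay limit

The source may report more compounds than this note shows. Statements on the series, on what has been measured and on what is new or still open speak of the compounds shown alone.

Compound 1 (`O=C(CSC(=S)N[C@H]1CCOC1=O)Nc1ccc(Cl)cc1`) gives > 128000 nM in a functional assay on EC9706 cells (Homo sapiens) for cytotoxicity, read by MTT assay, with a stated time of 72 h (a higher number here means a weaker inhibitor, a lower number a stronger inhibitor), and this is a limit of the assay, not a number. Compound 2 (`Cc1cccc(NC(=O)CSC(=S)N[C@H]2CCOC2=O)c1C`) gives > 128000 nM in this assay and this too is a limit. For the measured compounds named here, compound 1 therefore stands at the limit of > 128000 nM in this assay, at which 2 of the 2 values shown sit, and the series offers no measured step to work from.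

Compound 3 (`O=C(CSC(=S)N[C@H]1CCOC1=O)Nc1ccccc1`) is still unmeasured. The change from compound 1 to compound 3 is hydrogen in place of chloro on an aromatic carbon and amounts to hydrogen in place of chloro on an aromatic carbon, para to a large group, so that 4-chlorophenyl becomes phenyl.

No step beyond the scatter is expected in this assay and no direction can be named for this change, because compound 1 sits at > 128000 nM as a limit. The expected step that the limit leaves unreadable from compound 1 to compound 3 is an estimate and stays within the scatter. For compound 3 the expected value is 150000 nM with an estimated range from 70000 nM to 300000 nM and a report as a limit is the likeliest outcome.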

Compound 3, half-maximal inhibitory concentration: > 128000 nM
Compound 3: a limit, no number (the forecaster's own chance of this, stated with the estimate: 80%); the middle value lies beyond the limit too.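

Compound 1 and compound 3 both give limits rather than numbers in this assay, so no step from 4-chlorophenyl to phenyl can be read; all values shown sit at one limit: the limit of > 128000 nM in this assay, at which 3 of the 3 values shown sit.

The compounds shown leave open whether any member of this series gives a number in this assay, and whether 4-chlorophenyl and phenyl differ at all.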